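The compounds below may be only part of what the source reports. "The series", "measured", "known", "first", "only" and "open" are said of these compounds alone.

Compound 2, `Nc1ccc(S(=O)(=O)N2CCN(c3ncc(C(O)(C(F)(F)F)C(F)(F)F)cc3C#CC3CC3)CC2)cn1`, has been measured in an ADME assay (liver) for metabolic stability, with Liver microsome (Homo sapiens) as the target, using microsomes and NADPH, with a stated time of 30 min, tested at 1 uM; on this read-out lower numbers stand for slow clearance and higher numbers for fast clearance. There compound 2 gives < 14 mL.min-1.g-1, which is a limit of the assay rather than a number. Compound 1, `Nc1ccc(S(=O)(=O)N2CCN(c3ncc(C(O)(C(F)(F)F)C(F)(F)F)cc3Br)CC2)cn1`, likewise gives in this assay only a limit, < 14 mL.min-1.g-1. Compound 3, `CC(C)(O)C#Cc1cc(C(O)(C(F)(F)F)C(F)(F)F)cnc1N1CCN(S(=O)(=O)c2ccc(N)nc2)CC1`, also returns a limit in this assay, namely < 14 mL.min-1.g-1. The steps a step that the two limits leave unreadable from compound 1 to compound 2, a step that the two limits leave unreadable from compound 1 to compound 3 and a step that the two limits leave unreadable from compound 2 to compound 3 therefore cannot be sized, since (the limit of < 14 mL.min-1.g-1 in this assay, at which 3 of the 3 values shown sit). Compound 4, `Nc1ccc(S(=O)(=O)N2CCN(c3ncc(C(O)(C(F)(F)F)C(F)(F)F)cc3-c3ccoc3)CC2)cn1`, carries the change (furan-3-yl in place of 2-cyclopropylethynyl on an aromatic carbon). Among the compounds with values here, no measured step bears on it in a readable way, so no shift beyond the scatter can be argued for. Compound 4 is expected to give 10 mL.min-1.g-1, with a range from 5 mL.min-1.g-1 to 25 mL.min-1.g-1. The expected step is accordingly a step that the limit leaves unreadable from compound 2 to compound 4.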

Compound 4, intrinsic clearance in microsomes: < 14 mL.min-1.g-1
Compound 4 ended at the assay's limit; the forecaster's own chance of this, stated with the estimate: 70%; the middle value is on the limit's open side.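

Compound 4 gives only a limit in this assay, as do compound 1, compound 2 and compound 3, so none of its steps to them can be read: the limit of < 14 mL.min-1.g-1 in this assay, at which 4 of the 4 values shown sit.

From the compounds shown here alone, whether bromo, 2-cyclopropylethynyl, 3-hydroxy-3-methylbut-1-yn-1-yl and furan-3-yl differ at all in this assay stays open.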